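A few compounds are considered here, and "the series" means these few. Any claim that something is new, unique, unknown or untested is made for them only; others in the source may bear on it.

Working notes on the series. Among the compounds with values here, in a functional assay on HeLa cells (Homo sapiens) for cytotoxicity, read by MTT assay, with a stated time of 2 days (a lower number here means a stronger inhibitor, a higher number a weaker inhibitor), compound 1 (`Cc1cccc(-c2nc3cc(C)ccc3c(=O)[nH]2)c1`) gives 11200 nM as the higher of the two numbers measured so far. The only other reference point is compound 2 (`Cc1ccc2nc(-c3ccccc3C)[nH]c(=O)c2c1`) at 4580 nM as the lower number, and the gap between them lies beyond the usual scatter. Within the data shown here, no measured pair differs in one place only, so no measured step bears directly on the next change.

Compound 3 (`COc1cccc(-c2nc3cc(C)ccc3c(=O)[nH]2)c1`) departs from compound 1 by a single substitution: methoxy in place of methyl on an aromatic carbon gives methoxy in place of methyl on an aromatic carbon, with the rest of the structure unchanged. Among the measured compounds shown here, with no measured precedent for this swap, the expectation in this assay is a small step, probably none beyond the scatter, with a slight lean towards a lower number. The expected step is a 1.2-fold lower number from compound 1 to compound 3 (0.09 log units; within the scatter) and this remains a judgement from two values only. For compound 3 the estimated value is 9000 nM (expected range 3500 nM to 23000 nM).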

Compound 3, half-maximal inhibitory concentration: 8940 nM
The estimate for compound 3 lay 1.0-fold (0.00 log units) above the measured number; low and high end bracket the measured number.
By their numbers in this assay, from the lowest: compounds 2, 3 and 1 (each within the scatter of the next, the first and the last beyond it).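

In this assay, within the data shown here, methoxy in place of methyl on an aromatic carbon, meta to a large group, gives the first step that can be read at a single place: a 1.3-fold lower number from compound 1 to compound 3 (0.10 log units; within the scatter). At this place, then, the read-out does not separate the two groups, although the entering methoxy carries an oxygen and a hydrogen-bond acceptor that the departing methyl lacks, so this one swap gives no sign that the place responds to that difference. No independent measurement bears on this result, and the step offers no account of what lies behind it.

The compounds shown leave open whether this place tolerates any change in the group or only this swap, since a single small exchange cannot show how far the flat response extends, and an amine, a carboxylic acid or a longer chain such as ethoxy on the same aromatic carbon could still give a step beyond the scatter. They also leave open whether methoxy in place of methyl would give a similarly small step on other aromatic carbons of the core of compound 1.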